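The compounds below may be only part of what the source reports. "The series", "measured", "known", "first", "only" and "open" are said of these compounds alone.

Of the compounds shown here, three have so far been measured in a functional assay on MIA PaCa-2 cells (Homo sapiens) for inhibition, read by MTT assay, with a stated time of 3 days; on this read-out lower numbers stand for stronger inhibition and higher numbers for weaker inhibition. Compound 1 `CCOC(=O)[C@@H]1CCCN(S(=N)(=O)c2ccc(S(=O)(=O)N(CC)CC)cc2)C1` gives 4700 nM. Compound 2 `CCOC(=O)[C@@H]1CCC[C@@H](S(=O)(=O)c2ccc(S(=O)(=O)N(CC)CC)cc2)C1` gives 5000 nM. Compound 3 `CCCN(CCC)S(=O)(=O)c1ccc(S(=O)(=O)N2CCC[C@@H](C(=O)OCC)C2)cc1` gives 600 nM, the lowest of the three numbers; its gaps to compound 1 and to compound 2 both lie beyond the scatter, so compound 3 is the most potent of the set. Compound 4 `CCOC(=O)[C@@H]1CCCN(S(=O)(=O)c2ccc(S(=O)(=O)N3CCOCC3)cc2)C1` has not yet been measured. It differs from compound 3 in a single place: morpholin-4-yl in place of dipropylamino on a sulfonyl sulfur. Among the measured compounds shown here, no measured pair shows this change on its own, and the other two compounds differ from compound 3 in more than one place, so the step cannot be read off directly. For the measured compounds named here, the only guidance is that every departure from compound 3 seen so far sits far higher. The expected step is therefore a move to a higher number, somewhat beyond the scatter, namely a 3.3-fold higher number from compound 3 to compound 4 (0.52 log units; beyond the scatter). Compound 4 is estimated at 2000 nM, with a range from 500 nM to 8000 nM.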

Compound 4, half-maximal inhibitory concentration: 4100 nM
Beside the measured number, compound 4's estimate is 2.1-fold (0.31 log units) below it, within the range that was stated.
By their numbers in this assay, from the lowest: compound 3; then compounds 4, 1 and 2 (each within the scatter of the next).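

Changing only the group on this sulfonyl sulfur, with the rest of the molecule untouched, gives a 6.8-fold higher number from compound 3 to compound 4 (0.83 log units; beyond the scatter), so this position clearly affects the read-out. The change is also small in heavy-atom count, but it replaces an open dipropylamino group with a ring that carries one hydrogen-bond acceptor, and the low number of compound 3 does not survive it. No measurement shown here explains why this step occurs.

Going by these compounds, it remains open whether the loss of the propyl chains, the ring itself or the ring oxygen accounts for the step. Pyrrolidin-1-yl, a ring without oxygen, and dibutylamino, a longer open chain pair, do not appear on this sulfur among the compounds shown, so these contributions cannot be separated.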